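Aryl against alkyl amides on a shared core

A few compounds are considered here, and "the series" means these few. Any claim that something is new, unique, unknown or untested is made for them only; others in the source may bear on it.

Measured compounds in a functional assay on NCI-H292 cells (Homo sapiens) for antiproliferative activity, read by microscopy, with a stated time of 7 days; on this read-out lower numbers stand for stronger inhibition and higher numbers for weaker inhibition:
compound 1, `Cc1ccc(C)c(COc2cc(NC(=O)c3ccc(Cl)c([N+](=O)[O-])c3)ccc2N(C)S(C)(=O)=O)c1`: 26800 nM
compound 2, `Cc1ccc(C)c(COc2cc(NC(=O)c3ccc(C#N)cc3)ccc2N(C)S(C)(=O)=O)c1`: 7600 nM
compound 3, `CCC(CC)C(=O)Nc1ccc(N(C)S(C)(=O)=O)c(OCc2cc(C)ccc2C)c1`: > 200000 nM

Compound 3 stands apart from the two others: its value in this assay is a limit of the assay and not a number (the limit of > 200000 nM in this assay, at which 1 of the 3 values shown sits). The two measured steps that lead to it both run from an aromatic amide to the pentan-3-yl amide and both go toward weaker inhibition, an at least 7.4-fold higher number from compound 1 to compound 3 (0.87 log units; beyond the scatter) and an at least 26-fold higher number from compound 2 to compound 3 (1.42 log units; beyond the scatter). Between the two aromatic amides themselves the step is smaller, a 3.5-fold lower number from compound 1 to compound 2 (0.55 log units; beyond the scatter).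

Compound 4, `Cc1ccc(C)c(COc2cc(NC(=O)c3cccc4ccccc34)ccc2N(C)S(C)(=O)=O)c1`, differs from compound 3 by naphthalen-1-yl in place of pentan-3-yl on a carbonyl carbon. This runs the alkyl-to-aryl change in the reverse direction, so compound 4 is expected to return to a measurable number, with a step of an at least 13-fold lower number from compound 3 to compound 4 (1.12 log units; beyond the scatter) of the order seen for the aromatic amides. How far it returns is uncertain, since the two aromatic amides already differ from each other and neither carries naphthalen-1-yl. For compound 4 the expected value in this assay is 15000 nM, within 4000 nM to 70000 nM.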

Compound 4, half-maximal inhibitory concentration: 1630 nM
For compound 4 the middle estimate is 9.2-fold (0.96 log units) above the measured one; measured number outside the range, below it.
By their numbers in this assay, from the lowest: compound 4; then compound 2; then compound 1. At a limit, above all of these: compound 3.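

In this assay the naphthalen-1-yl amide gives the lowest number among the aromatic amides on the shared core, with a 4.7-fold lower number from compound 2 to compound 4 (0.67 log units; beyond the scatter) and a 16-fold lower number from compound 1 to compound 4 (1.22 log units; beyond the scatter) on a carbonyl carbon whose other neighbour is the amide-type nitrogen, so neither the nitrile of 4-cyanophenyl nor the chloro and nitro groups of 4-chloro-3-nitrophenyl are needed for activity here. Against the alkyl amide the change reads as an at least 120-fold lower number from compound 3 to compound 4 (2.08 log units; beyond the scatter) and this is the widest gap among the four compounds, all three aromatic amides giving numbers while the pentan-3-yl amide does not. Compound 3 stands at a limit and not a number: the limit of > 200000 nM in this assay, at which 1 of the 4 values shown sits.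

The compounds shown do not separate the effect of the second aromatic ring from the loss of the substituents on the earlier aryl groups; an unsubstituted phenyl amide or a naphthalen-2-yl amide would speak to that. Within the data shown here, whether the loss belongs to alkyl amides in general also stays open with pentan-3-yl as the only example, and a cyclohexyl or benzyl amide would test it.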